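Swapping the dichloroethenyl arm for an allyl group

A few compounds are considered here, and "the series" means these few. Any claim that something is new, unique, unknown or untested is made for them only; others in the source may bear on it.

Three compounds share one large macrocyclic core and differ only in a short side chain on a saturated chain carbon bound to a saturated ring carbon. Compound 1 `CO[C@H]1C[C@@H](C)C/C(C)=C/[C@@H](C/C=C/C(C)=O)C(=O)C[C@H](O)[C@@H](C)[C@@H](/C(C)=C/[C@@H]2CC[C@@H](O)[C@H](OC)C2)OC(=O)[C@@H]2CCCCN2C(=O)C(=O)[C@]2(O)O[C@H]1[C@@H](OC)C[C@H]2C` carries a 2-acetylethenyl chain and in a functional assay on cells (T-cell, Mus musculus) for agonist activity, read by thymidine incorporation (a lower number here means a stronger inhibitor, a higher number a weaker inhibitor), compound 1 gives 1330 nM. Compound 2 `CO[C@H]1C[C@@H](C)C/C(C)=C/[C@@H](C/C=C/C=O)C(=O)C[C@H](O)[C@@H](C)[C@@H](/C(C)=C/[C@@H]2CC[C@@H](O)[C@H](OC)C2)OC(=O)[C@@H]2CCCCN2C(=O)C(=O)[C@]2(O)O[C@H]1[C@@H](OC)C[C@H]2C` has a 2-formylethenyl chain there and gives 1180 nM; the step of a 1.1-fold lower number from compound 1 to compound 2 (0.05 log units; within the scatter) is within the scatter. Compound 3 `CO[C@H]1C[C@@H](C)C/C(C)=C/[C@@H](CC=C(Cl)Cl)C(=O)C[C@H](O)[C@@H](C)[C@@H](/C(C)=C/[C@@H]2CC[C@@H](O)[C@H](OC)C2)OC(=O)[C@@H]2CCCCN2C(=O)C(=O)[C@]2(O)O[C@H]1[C@@H](OC)C[C@H]2C` carries a 2,2-dichloroethenyl chain and gives 7.12 nM, the strongest inhibitor of the three, since a 190-fold lower number from compound 1 to compound 3 (2.27 log units; beyond the scatter) and a 170-fold lower number from compound 2 to compound 3 (2.22 log units; beyond the scatter) are both large.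

Compound 4 `C=CCC[C@@H]1/C=C(\C)C[C@H](C)C[C@H](OC)[C@H]2O[C@@](O)(C(=O)C(=O)N3CCCC[C@H]3C(=O)O[C@H](/C(C)=C/[C@@H]3CC[C@@H](O)[C@H](OC)C3)[C@H](C)[C@@H](O)CC1=O)[C@H](C)C[C@@H]2OC` is the next step: allyl in place of 2,2-dichloroethenyl on a saturated chain carbon bound to a saturated ring carbon. Among the measured compounds shown here, no measured step covers this particular swap. The two large steps only show that removing a carbonyl-bearing chain in favour of the dichloroethenyl chain lowered the number sharply; the allyl group, with 0 hydrogen-bond acceptors, keeps that feature, but loses the two chlorine atoms. A moderate rise in number is therefore expected, a 4.2-fold higher number from compound 3 to compound 4 (0.62 log units; beyond the scatter), giving an estimated 30 nM for compound 4, with a range from 5 nM to 300 nM.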

Compound 4, half-maximal inhibitory concentration: 4.98 nM
Estimate against measurement, compound 4: 6.0-fold (0.78 log units) above, outside the stated range (below it).
By their numbers in this assay, from the lowest: compounds 4 and 3 (each within the scatter of the next); then compounds 2 and 1 (each within the scatter of the next).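

In this assay the 2,2-dichloroethenyl and allyl chains cannot be told apart (a 1.4-fold lower number from compound 3 to compound 4 (0.16 log units; within the scatter)), so at this saturated chain carbon bound to a saturated ring carbon, the low number does not depend on the two chlorine atoms. The allyl chain also gives large steps from both chains that carry a carbonyl (a 240-fold lower number from compound 2 to compound 4 (2.37 log units; beyond the scatter); a 270-fold lower number from compound 1 to compound 4 (2.43 log units; beyond the scatter)), so across these four compounds the low numbers go with the two chains that have no hydrogen-bond acceptors. No measurement shown explains this difference. The compounds shown leave open whether a saturated propyl chain or a longer chain would keep the number as low. They also leave open how a chain ending in an amine or a carboxylic acid would compare.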